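This account rests on a few compounds, and the source may have more. Where it says the series, first, only, none or still open, it means among the compounds named here.

Measured in a functional assay on the whole organism (stomach) with Rattus norvegicus as the target; on this read-out lower numbers stand for an effect already at smaller amounts and higher numbers for an effect only at larger amounts of compound:
- compound 1 `CCCc1ccc(C(=O)Nc2cc(C(=O)O)cc(C(=O)O)c2)cc1`: 94.2 mg/kg
- compound 2 `CCCCc1ccc(C(=O)Nc2cc(C(=O)O)cc(C(=O)O)c2)cc1`: 91.9 mg/kg
- compound 3 `O=C(O)c1cc(NC(=O)c2ccc(-c3nn[nH]n3)cc2)cc(C(=O)O)c1`: 8.2 mg/kg

Compound 3 has the lowest number of the three, so it acts at the smallest dose. The next compound to consider is compound 4 `CCCOc1ccc(C(=O)Nc2cc(C(=O)O)cc(C(=O)O)c2)cc1`, which has not yet been measured. It has propoxy in place of 2H-tetrazol-5-yl on an aromatic carbon, para to a large group: propoxy in place of 2H-tetrazol-5-yl on an aromatic carbon.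

Going by the values given here, no measured step makes exactly this swap, and no measured compound carries propoxy. Two steps come close, though they run in the opposite direction, with a carbon chain leaving and 2H-tetrazol-5-yl entering. These are an 11-fold lower number from compound 1 to compound 3 (1.06 log units; beyond the scatter) and an 11-fold lower number from compound 2 to compound 3 (1.05 log units; beyond the scatter), both large and beyond the scatter. A third step, a 1.0-fold lower number from compound 1 to compound 2 (0.01 log units; within the scatter), lies within the scatter, so the extra methyl made no visible difference.

Reversing the large steps suggests that removing 2H-tetrazol-5-yl will give a similarly large rise in this assay, with the uncertainty that propoxy is not a plain carbon chain. The estimated change is a 9.8-fold higher number from compound 3 to compound 4 (0.99 log units; beyond the scatter). For compound 4 the expected value is 80 mg/kg. The estimated range for compound 4 runs from 35 mg/kg to 170 mg/kg.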

Compound 4, dose for 50% inhibition: 78 mg/kg
Compound 4: middle estimate off by 1.0-fold (0.01 log units), on the high side, and the stated range covers the measured number.
By their numbers in this assay, from the lowest: compound 3; then compounds 4, 2 and 1 (each within the scatter of the next).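

In this assay, going by these compounds alone, propoxy in place of 2H-tetrazol-5-yl gives a 9.5-fold higher number from compound 3 to compound 4 (0.98 log units; beyond the scatter), and this is the first sign that a group holding oxygen, rather than a plain carbon chain, also loses the low number seen with the tetrazole. Against the two chains, the change gives a 1.2-fold lower number from compound 2 to compound 4 (0.07 log units; within the scatter) and a 1.2-fold lower number from compound 1 to compound 4 (0.08 log units; within the scatter), both within the scatter, so on this aromatic carbon, para to a large group, the propyl, butyl and propoxy compounds cannot be told apart, and only compound 3 stands away from them. No measurement shown here accounts for this separation of the tetrazole from the other three groups.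

As far as these compounds go, what remains open is whether the low number needs the five-membered aromatic ring with its hetero atoms, or whether a smaller group such as a carboxylic acid or an amine at the same place would give a similar result. A phenyl ring there would also help to separate the effect of having any ring at all from that of the tetrazole itself.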